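Hydroxymethyl to 2-Hydroxyethyl on the Thiazole Side Chain

This account rests on a few compounds, and the source may have more. Where it says the series, first, only, none or still open, it means among the compounds named here.

Compound 1 `Cc1ccc(NC(=O)C(=O)NC(c2nc(C)c(CCO)s2)C2CCCCN2)c(F)c1`, a limit in an ADME assay on TZM-b1 cells (Homo sapiens) for cytotoxicity, read by XTT assay, with a stated time of 3 days; a higher number here means that more compound is tolerated, a lower number that less compound is tolerated: > 78800 nM
Compound 2 `Cc1nc(C(NC(=O)C(=O)Nc2ccc(Cl)c(F)c2)C2CCCCN2)sc1CCO` in this assay: 61000 nM
Compound 3 `Cc1nc(C(NC(=O)C(=O)Nc2ccc(F)cc2F)C2CCCCN2)sc1CO`, a limit in this assay: > 87000 nM

In this assay compound 3 gives only a limit, not a number, and that limit is the limit of > 87000 nM in this assay, at which 1 of the 3 values shown sits. Compound 1 likewise gives only a limit, (the limit of > 78800 nM in this assay, at which 1 of the 3 values shown sits). Among the measured compounds shown here, compound 2 is the one measured compound that gives an actual number. For the measured compounds named here, the single measured step, an at least 1.2-fold lower number from compound 1 to compound 2 (0.11 log units; that floor lies within the scatter), exchanges one aryl group for another on the amide nitrogen and sits within the scatter at its floor; it says nothing about the side chain on the shared core.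

Compound 4 `Cc1nc(C(NC(=O)C(=O)Nc2ccc(F)cc2F)C2CCCCN2)sc1CCO` differs from compound 3 by hydroxymethyl in place of hydroxy on a saturated chain carbon bound to an aromatic carbon. Going by the values given here, no measured step covers this change, so no direction can be read from the data. Compounds 1 and 2, which carry the 2-hydroxyethyl chain, sit at a limit and at a number near it, which suggests tolerance stays high. The expected step is an at least 1.0-fold lower number from compound 3 to compound 4 (0.01 log units; that floor lies within the scatter), nothing beyond the scatter. Compound 4 is therefore estimated at 85000 nM, with a range from 45000 nM to 130000 nM, most likely again reported only as a limit.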

Compound 4, half-maximal cytotoxic concentration: > 84000 nM
Compound 4: only a limit was reported (the forecaster's own chance of this, stated with the estimate: 65%); the middle value does not contradict the limit.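

In this assay compound 4 also gives only a limit, so with the 2,4-difluorophenyl group on the amide-type nitrogen, the 2-hydroxyethyl chain and the hydroxymethyl chain of compound 3 both end in a limit rather than a number: the limit of > 84000 nM in this assay, at which 1 of the 4 values shown sits. The steps linking compound 4 to compound 3 and to compound 1 join two limits and cannot be read, so this change of side chain has no measured size. Among the compounds shown here, the one readable new step is an at least 1.3-fold higher number from compound 2 to compound 4 (0.13 log units; that floor lies within the scatter), and it exchanges 4-chloro-3-fluorophenyl for 2,4-difluorophenyl on an amide-type nitrogen, leaving the side chain as it was.

For the compounds shown here, no pair differing only in this chain has a number on both sides, so whether the change shifts tolerance at all stays open. Also open, from the compounds shown here alone, is how a longer chain such as 3-hydroxypropyl, or an amine or a carboxylic acid in place of the hydroxy, would behave on the shared core.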